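Benzofuranyl-to-thiophenyl swap on a nucleoside series with limits only

The source may hold more compounds than are shown below. What is called first, only, known or untested is meant among the compounds shown, and "the series" means these compounds.

Measured so far:
compound 1 `CN(C)c1ncnc2c1c(-c1cc3ccccc3o1)cn2[C@@H]1O[C@H](CO)[C@@H](O)[C@H]1O` — > 20000 nM
compound 2 `Cc1ncnc2c1c(-c1cc3ccccc3o1)cn2[C@@H]1O[C@H](CO)[C@@H](O)[C@H]1O` — > 20000 nM
compound 3 `CNc1ncnc2c1c(-c1cc3ccccc3o1)cn2[C@@H]1O[C@H](CO)[C@@H](O)[C@H]1O` — > 20000 nM

In a functional assay on K562 cells (Homo sapiens), read by MTT assay, with a stated time of 72 h (a lower number here means a stronger inhibitor, a higher number a weaker inhibitor), compound 1 gives > 20000 nM, which is a limit of the assay and not a number. For compound 2 the result in this assay is > 20000 nM, again only a limit. Compound 3 likewise reaches only the limit > 20000 nM in this assay. Every value shown therefore sits at the limit of > 20000 nM in this assay, at which 3 of the 3 values shown sit, and compound 1 stands on that limit with no numeric reading to place it against the others.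

The steps among the measured compounds are a step that the two limits leave unreadable from compound 1 to compound 2, a step that the two limits leave unreadable from compound 1 to compound 3 and a step that the two limits leave unreadable from compound 2 to compound 3; none of them can be sized, because the two limits hide any change (the limit of > 20000 nM in this assay, at which 3 of the 3 values shown sit).

Compound 4 `CN(C)c1ncnc2c1c(-c1cccs1)cn2[C@@H]1O[C@H](CO)[C@@H](O)[C@H]1O` differs from compound 1 by thiophen-2-yl in place of 1-benzofuran-2-yl on an aromatic carbon. Going by the values given here, no measured step touches this position, so nothing here reads on the change directly. Since compound 1 sits at the limit of > 20000 nM in this assay, at which 3 of the 3 values shown sit, compound 4 is expected to remain near that limit as well, with a step that the limit leaves unreadable from compound 1 to compound 4 as the expected step. For compound 4 the estimate in this assay is 30000 nM, ranging from 8000 nM to 100000 nM.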

Compound 4, half-maximal inhibitory concentration: > 20000 nM
Compound 4: no number, only a limit; the forecaster's own chance of this, stated with the estimate: 75%; the middle value lies beyond the limit too.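

In this assay compound 4 gives > 20000 nM, a limit and not a number, so the step from the 1-benzofuran-2-yl of compound 1 to the thiophen-2-yl of compound 4 cannot be read, nor can any other step: the limit of > 20000 nM in this assay, at which 4 of the 4 values shown sit.

The compounds shown leave open how these two groups compare, and which change to the shared core would give a numeric reading in this assay.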